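Dimethylaminophenyl in place of methylthiophenyl

The source may report more compounds than this note shows. Statements on the series, on what has been measured and on what is new or still open speak of the compounds shown alone.

Within the data shown here, in a functional assay on DU-145 cells (Homo sapiens) for inhibition, read by trypan blue exclusion, with a stated time of 96 h (on this read-out higher numbers stand for weaker inhibition of growth and lower numbers for stronger inhibition of growth), compound 2 `Cc1ccc(CS/C(=C/c2sccc2C)C(=O)c2ccc(Cl)cc2)cc1` gives 10000 nM, the only number obtained so far. Compound 1 `Cc1ccc(S/C(=C/c2ccc(N(C)C)cc2)C(=O)c2ccc(Cl)cc2)cc1` returns a limit rather than a number, > 100000 nM in this assay. Compound 3 `Cc1ccc(CS/C(=C/c2ccc(N(C)C)cc2)C(=O)c2ccc(Cl)cc2)cc1` has not yet been tested; it differs from compound 2 by 4-(dimethylamino)phenyl in place of 3-methylthiophen-2-yl on a double-bonded chain carbon bound to a double-bonded chain carbon. Among the measured compounds shown here, no measured pair follows this single change, so no directly comparable step exists. Compound 1 carries the same entering group and gives only a limit. Compound 3 is accordingly expected to be weaker, with an estimated step of a 3.0-fold higher number from compound 2 to compound 3 (0.48 log units; beyond the scatter). Compound 3 is thus expected to give 30000 nM, within a range from 8000 nM to 150000 nM.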

Compound 3, concentration for 50% growth inhibition: > 100000 nM
Compound 3: only a limit was reported; the forecaster's own chance of this, stated with the estimate: 35%; middle value at least 3.3-fold (0.52 log units) from the limit.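

In this assay, 4-(dimethylamino)phenyl in place of 3-methylthiophen-2-yl on a double-bonded chain carbon bound to a double-bonded chain carbon gives an at least 10-fold higher number from compound 2 to compound 3 (1.00 log units; beyond the scatter) and so gives the first readable sign that this position affects growth inhibition. The full size of this step stays hidden behind a limit: the limit of > 100000 nM in this assay, at which 2 of the 3 values shown sit. The step from compound 1 to compound 3 cannot be read. Going by these compounds, it remains open whether the loss follows the six-membered ring itself or its dimethylamino group, which a plain phenyl at this position would separate.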